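Compound 3: 3-methoxyphenyl in place of 2-methoxyphenyl

A few compounds are considered here, and "the series" means these few. Any claim that something is new, unique, unknown or untested is made for them only; others in the source may bear on it.

In a functional assay on MCF7 cells (Homo sapiens) for inhibition, read by MTT assay, with a stated time of 3 days (a lower number here means a stronger inhibitor, a higher number a weaker inhibitor), compound 1 (`C/C=C/COc1cc(/C=C\c2cc(OC)c(OC)c(OC)c2)ccc1OC`) gives 5400 nM and compound 2 (`COc1ccccc1/C=C/CCCOc1cc(/C=C\c2cc(OC)c(OC)c(OC)c2)ccc1OC`) gives 21000 nM as the higher of the two numbers, which makes it the weaker inhibitor of the pair. Compound 3 (`COc1cccc(/C=C/CCCOc2cc(/C=C\c3cc(OC)c(OC)c(OC)c3)ccc2OC)c1`) has not yet been measured and differs from compound 2 in one place (3-methoxyphenyl in place of 2-methoxyphenyl on a double-bonded chain carbon bound to a double-bonded chain carbon), with 3-methoxyphenyl in place of 2-methoxyphenyl on a double-bonded chain carbon bound to a double-bonded chain carbon. Within the data shown here, the one measured step (a 3.9-fold higher number from compound 1 to compound 2 (0.59 log units; beyond the scatter)) is modest but beyond the scatter, and it replaced prop-1-en-1-yl with 4-(2-methoxyphenyl)but-3-en-1-yl. Among the measured compounds shown here, no measured pair shows a change of the present kind, so that step bears on it only loosely, and no change beyond the scatter is expected in this assay in either direction. The expected step (a 1.2-fold lower number from compound 2 to compound 3 (0.07 log units; within the scatter)) is accordingly small. For compound 3 the estimated value is 18000 nM with an expected range from 7000 nM to 45000 nM in this measurement.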

Compound 3, half-maximal inhibitory concentration: 41000 nM
For compound 3 the middle estimate is 2.3-fold (0.36 log units) below the measured one; measured number inside the range.
By their numbers in this assay, from the lowest: compound 1; then compounds 2 and 3 (each within the scatter of the next).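

In this assay the exchange of 2-methoxyphenyl for 3-methoxyphenyl on a double-bonded chain carbon bound to a double-bonded chain carbon amounts to a 2.0-fold higher number from compound 2 to compound 3 (0.29 log units; within the scatter) and so does not separate the two compounds. The exchange of prop-1-en-1-yl for 4-(3-methoxyphenyl)but-3-en-1-yl gives a 7.6-fold higher number from compound 1 to compound 3 (0.88 log units; beyond the scatter) and thus places compound 1 on the stronger side with either methoxyphenyl chain, since compound 2 stands on the same side of it as compound 3. No measurement at hand offers an explanation for either result.

Still open, on these data alone, is whether an unsubstituted phenyl, a pyridine ring or an amine at the end of this chain would read differently from compound 2 and compound 3. Also open, as far as these compounds go, is whether a shorter chain carrying the ring would come closer to compound 1.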